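Taking the Methyl Off Compound 1's Ring Nitrogen

The source may report more compounds than this note shows. Statements on the series, on what has been measured and on what is new or still open speak of the compounds shown alone.

In an ADME assay on L02 cells (Homo sapiens) for cytotoxicity, read by MTT assay, with a stated time of 24 h (on this read-out higher numbers stand for weaker inhibition and lower numbers for stronger inhibition), compound 1 (`CN1C/C(=C\c2ccncc2)C(=O)/C(=C/c2ccccc2F)C1`) gives 14900 nM. Compound 2 (`CN1C/C(=C\c2ccncc2)C(=O)/C(=C/c2cc([N+](=O)[O-])ccc2F)C1`) gives 17600 nM, and compound 3 (`CN1C/C(=C\c2ccncc2)C(=O)/C(=C/c2ccc(C#N)cc2)C1`) gives 14000 nM. Compound 1 therefore sits among three numbers that all lie within the usual scatter of one another, so they cannot be meaningfully ranked.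

The unmeasured compound 4 (`O=C1/C(=C/c2ccncc2)CNC/C1=C\c1ccccc1F`) has hydrogen in place of methyl on an amine nitrogen in a ring. Within the data shown here, only two measured steps offer guidance, and both are changes made elsewhere on the molecule. One is a 1.2-fold higher number from compound 1 to compound 2 (0.07 log units; within the scatter), and the other is a 1.1-fold lower number from compound 1 to compound 3 (0.03 log units; within the scatter). Neither tests the amine nitrogen, so they are only an indirect guide. With both steps this small, no shift beyond the scatter is expected in this assay, and neither direction is favoured. The expected step is a 1.0-fold higher number from compound 1 to compound 4 (0.00 log units; within the scatter). For compound 4, the estimated value is 15000 nM, with an expected range from 7000 nM to 32000 nM.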

Compound 4, half-maximal inhibitory concentration: 14700 nM
Estimate against measurement, compound 4: 1.0-fold (0.01 log units) above; the range from low to high includes it.
By their numbers in this assay, from the lowest: compounds 3, 4, 1 and 2 (each within the scatter of the next).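

Compound 2 and compound 3 differ from compound 1 elsewhere on the molecule, so they said nothing about the amine nitrogen in the ring. In this assay, hydrogen in place of methyl at this nitrogen gives a 1.0-fold lower number from compound 1 to compound 4 (0.01 log units; within the scatter), which shows that, on the core of compound 1, this methyl can be removed without a shift beyond the scatter. No measurement shown here accounts for this result.

As far as these compounds go, whether a longer chain such as ethyl, a benzyl group or an acetyl group on this nitrogen would also stay within the scatter remains open. Also open, from the compounds shown here alone, is whether hydrogen at this nitrogen would give the same picture when paired with the nitro or 4-cyanophenyl changes of compound 2 and compound 3.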